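Aryl group change from compound 2 to compound 3

A few compounds are considered here, and "the series" means these few. Any claim that something is new, unique, unknown or untested is made for them only; others in the source may bear on it.

In a functional assay on A549 cells (Homo sapiens) for antiproliferative activity, read by MTT assay, with a stated time of 72 h (on this read-out lower numbers stand for stronger inhibition and higher numbers for weaker inhibition), compound 1 (`Nc1nc(N)c2cc(CSC(=S)N3CCN(c4ccc(Cl)cc4)CC3)ccc2n1`) gives 5210 nM and compound 2 (`Nc1nc(N)c2cc(CSC(=S)N3CCN(c4ccccc4F)CC3)ccc2n1`) gives 6460 nM. Within the data shown here, these are the only two numbers so far, and they lie within the scatter of each other, so compound 2 has no separate rank.

Compound 3 (`CC(=O)c1ccc(N2CCN(C(=S)SCc3ccc4nc(N)nc(N)c4c3)CC2)cc1`) keeps the shared core and has 4-acetylphenyl in place of 2-fluorophenyl on an amine nitrogen in a ring.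

Among the measured compounds shown here, one measured step bears on this change: a 1.2-fold higher number from compound 1 to compound 2 (0.09 log units; within the scatter), an exchange of one substituted phenyl for another on that same nitrogen. Neither measured compound carries an acetyl group, so the evidence is indirect and the range stays wide. Given that small step, no change beyond the scatter is expected in this assay. The expected step is a 1.1-fold lower number from compound 2 to compound 3 (0.03 log units; within the scatter). For compound 3 the estimate is 6000 nM, with an expected range of 2500 nM to 14000 nM.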

Compound 3, half-maximal inhibitory concentration: 2550 nM
For compound 3 the middle estimate is 2.4-fold (0.37 log units) above the measured one, and the stated range covers the measured number.
By their numbers in this assay, from the lowest: compound 3; then compounds 1 and 2 (each within the scatter of the next).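

In this assay, among these compounds, the aryl group on the amine nitrogen in the ring moves the number beyond the scatter for the first time: a 2.5-fold lower number from compound 2 to compound 3 (0.40 log units; beyond the scatter) comes with 4-acetylphenyl in place of 2-fluorophenyl, and a 2.0-fold lower number from compound 1 to compound 3 (0.31 log units; beyond the scatter) comes with acetyl in place of chloro on an aromatic carbon. This position is therefore not silent, as compounds 1 and 2 alone might have suggested, although both steps are modest and compound 3 stands lowest of the three. No measurement in hand explains the difference.

Going by these compounds, whether the lower number belongs to the acetyl group itself remains open, since a nitrile, a methyl ester or a primary amide on the same phenyl ring could show whether other groups behave alike. Among the compounds shown here, only one acetyl-bearing compound is available, so the series gives no trend yet.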